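Notes on sulfonamide N-methylation in the pyrimidine series

A few compounds are considered here, and "the series" means these few. Any claim that something is new, unique, unknown or untested is made for them only; others in the source may bear on it.

Compound 3 `CNS(=O)(=O)c1ccc(Nc2ncc3c(n2)N(C)C(c2ccccc2C)C(=O)N3C)cc1` gives 104 nM in an assay on Sf9 cells for inhibition of serine/threonine-protein kinase 4 (Homo sapiens), read by luminescence and ADP-Glo, with a stated time of 1 h, in the presence of a further agent that is not named here (a lower number here means a stronger inhibitor, a higher number a weaker inhibitor), second highest of the three numbers shown. Compound 1 `CN1C(=O)C(c2ccccc2F)N(C)c2nc(Nc3ccc(S(N)(=O)=O)cc3)ncc21` gives 75 nM, within the scatter of compound 3; compound 2 `CNS(=O)(=O)c1ccc(Nc2ncc3c(n2)N(C)C(c2c(F)cccc2F)C(=O)N3C)cc1` gives 318 nM, and the step of a 3.1-fold lower number from compound 2 to compound 3 (0.49 log units; beyond the scatter) is modest but beyond the scatter. Compound 4 `Cc1ccccc1C1C(=O)N(C)c2cnc(Nc3ccc(S(=O)(=O)N(C)C)cc3)nc2N1C` differs from compound 3 only by methyl in place of hydrogen on a sulfonamide nitrogen. For the measured compounds named here, no measured step changes the sulfonamide nitrogen; the only sulfonamide contrast, compound 1 against compound 3, also changes the aryl group, and their two values sit within the scatter. The step is therefore expected to be a 1.3-fold higher number from compound 3 to compound 4 (0.10 log units; within the scatter), in no clear direction. Compound 4 is estimated at 130 nM, with a range of 45 nM to 380 nM.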

Compound 4, half-maximal inhibitory concentration: 219 nM
The estimate for compound 4 lay 1.7-fold (0.23 log units) below the measured number, and the stated range covers the measured number.
By their numbers in this assay, from the lowest: compounds 1 and 3 (each within the scatter of the next); then compounds 4 and 2 (each within the scatter of the next).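

Methylsulfamoyl to dimethylsulfamoyl gives the first measured step that changes the sulfonamide nitrogen alone: in this assay, the change reads a 2.1-fold higher number from compound 3 to compound 4 (0.32 log units; beyond the scatter) and so goes toward weaker inhibition. With the 2-methylphenyl group held fixed, this step is free of the aryl change that accompanies the contrast between compound 1 and compound 3. No measurement here bears on the reason for the step.

Still open, from the compounds shown here alone, is whether the weakening continues with a longer chain on this nitrogen, such as ethyl or propyl. Also open, going by these compounds, is how a chain ending in an amine or a carboxylic acid would read there.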